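Moving the benzodioxin attachment on the amide carbonyl

The compounds below may be only part of what the source reports. "The series", "measured", "known", "first", "only" and "open" are said of these compounds alone.

Measured compounds in a functional assay on WM 266-4 cells (Homo sapiens) for inhibition, read by MTT assay, with a stated time of 24 h; a higher number here means a weaker inhibitor of growth, a lower number a stronger inhibitor of growth:
- compound 1 `COc1ccc(C2CC(c3ccc(Br)cc3)=NN2C(=O)c2ccc3c(c2)OCCO3)cc1`: 5680 nM
- compound 2 `O=C(c1ccc2c(c1)OCCO2)N1N=C(c2ccc(Br)cc2)CC1c1ccccc1`: 1790 nM
- compound 3 `O=C(C1COc2ccccc2O1)N1N=C(c2ccc(Br)cc2)CC1c1cccc(F)c1`: 7810 nM

Compound 3 gives the highest number of the three in this assay, so it is the weakest inhibitor of growth among them, though its gap to compound 1 lies within the usual scatter; only its gap to compound 2 is beyond it.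

Compound 4 `O=C(c1ccc2c(c1)OCCO2)N1N=C(c2ccc(Br)cc2)CC1c1cccc(F)c1` is built from the same atoms as compound 3, joined differently: 2,3-dihydro-1,4-benzodioxin-6-yl in place of 2,3-dihydro-1,4-benzodioxin-2-yl on a carbonyl carbon. The rest of the molecule is unchanged.

Going by the values given here, none of the measured steps makes this exact change. Among the compounds with values here, the only one-place step known is a 3.2-fold lower number from compound 1 to compound 2 (0.50 log units; beyond the scatter), which concerns a different part of the molecule and says nothing directly about how the benzodioxin ring is attached. What the data do show is that compound 2, which shares the benzodioxin-6-yl amide of compound 4, sits well below compound 3. On that basis compound 4 is expected to move towards compound 2, giving a step of a 3.1-fold lower number from compound 3 to compound 4 (0.49 log units; beyond the scatter). The estimate for compound 4 is therefore 2500 nM, within a range from 900 nM to 7000 nM.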

Compound 4, concentration for 50% growth inhibition: 810 nM
For compound 4 the middle estimate is 3.1-fold (0.49 log units) above the measured one; measured number outside the range, below it.
By their numbers in this assay, from the lowest: compound 4; then compound 2; then compounds 1 and 3 (each within the scatter of the next).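

In this assay the attachment point of the benzodioxin on the amide carbonyl matters in its own right: with the rest of the molecule unchanged, 2,3-dihydro-1,4-benzodioxin-6-yl in place of 2,3-dihydro-1,4-benzodioxin-2-yl gives a 9.6-fold lower number from compound 3 to compound 4 (0.98 log units; beyond the scatter) and so a clearly stronger inhibitor of growth. With the 6-yl attachment in place, the other ring also counts: fluoro in place of hydrogen on an aromatic carbon gives a 2.2-fold lower number from compound 2 to compound 4 (0.34 log units; beyond the scatter) and 3-fluorophenyl in place of 4-methoxyphenyl on a saturated ring carbon gives a 7.0-fold lower number from compound 1 to compound 4 (0.85 log units; beyond the scatter) in the same direction. Nothing available here offers a reason for these steps.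

From the compounds shown here alone, the attachment change is seen in this one pair only, so its size with other rings on the core remains open. Going by these compounds, how a chloro, a nitrile or an amine would compare with fluoro on that aromatic ring also remains open.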